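This account rests on a few compounds, and the source may have more. Where it says the series, first, only, none or still open, it means among the compounds named here.

Measured so far in an ADME assay on CCRF-HSB-2 cells (Homo sapiens) for cytotoxicity, with a stated time of 7 days; on this read-out lower numbers stand for higher toxicity in this test and higher numbers for lower toxicity in this test:
Compound 1, `CCCCCCCCOc1nc(N)nc2c1ncn2/C=C1/CC1(CO)CO`, gives > 20000 nM, which is a limit of the assay rather than a number.
Compound 2, `CCCCSc1nc(N)nc2c1ncn2/C=C1/CC1(CO)CO`, gives 89000 nM.
Compound 3, `Nc1nc(NC2CCCCC2)c2ncn(/C=C3/CC3(CO)CO)c2n1`, gives > 20000 nM, again a limit of the assay rather than a number.

Compound 3 thus stands at the limit of > 20000 nM in this assay, at which 2 of the 3 values shown sit. Compound 4, `CCCNc1nc(N)nc2c1ncn2/C=C1/CC1(CO)CO`, is still unmeasured; it differs from compound 3 by propyl in place of cyclohexyl on a nitrogen on an aromatic ring. The steps that lead into compound 3 are a step that the two limits leave unreadable from compound 1 to compound 3 and a step that the limit leaves unreadable from compound 2 to compound 3, so neither gives a readable size or direction. With nothing readable to build on, compound 4 is expected to behave like compound 3, at an expected step that the limit leaves unreadable from compound 3 to compound 4. Compound 4 is therefore estimated at 50000 nM, within 20000 nM to 200000 nM, most likely reported only as a limit.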

Compound 4, half-maximal cytotoxic concentration: > 20000 nM
Compound 4 ended at the assay's limit; the forecaster's own chance of this, stated with the estimate: 70%; the middle value is on the limit's open side.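

In this assay, within the data shown here, compound 4 gives a limit rather than a number, and no step to it from compound 1, compound 2 or compound 3 can be read. The compounds shown leave open whether changing the group on the aromatic carbon alters toxicity in this test at all.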